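The source may report more compounds than this note shows. Statements on the series, on what has been measured and on what is new or still open speak of the compounds shown alone.

Within the data shown here, compound 2 `Cc1cc(SC(C)C)c(S(C)(=O)=O)cc1C(=O)N=C(N)N` stands lowest of the two numbers so far: in a functional assay for inhibition of sodium/hydrogen exchanger (Oryctolagus cuniculus) (on this read-out lower numbers stand for stronger inhibition and higher numbers for weaker inhibition), compound 2 gives 12 nM, while compound 1 `Cc1cc(-c2ccc(Cl)cc2)c(S(C)(=O)=O)cc1C(=O)N=C(N)N` gives 45 nM. The step ahead is benzyloxy in place of isopropylsulfanyl on an aromatic carbon, giving compound 3 `Cc1cc(OCc2ccccc2)c(S(C)(=O)=O)cc1C(=O)N=C(N)N`. Among the measured compounds shown here, the one measured step that bears on it is a 3.8-fold lower number from compound 1 to compound 2 (0.57 log units; beyond the scatter), where a six-membered aromatic ring left that aromatic carbon and the number fell. Compound 3 brings an aromatic ring back to that carbon, so a modest rise in this assay is expected, a 2.5-fold higher number from compound 2 to compound 3 (0.40 log units; beyond the scatter). Compound 3 is estimated at 30 nM, range 8 nM to 120 nM.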

Compound 3, half-maximal inhibitory concentration: 28 nM
Compound 3: middle estimate off by 1.1-fold (0.03 log units), on the high side; low and high end bracket the measured number.
By their numbers in this assay, from the lowest: compound 2; then compounds 3 and 1 (each within the scatter of the next).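

In this assay the change gives a 2.3-fold higher number from compound 2 to compound 3 (0.37 log units; beyond the scatter) and so isopropylsulfanyl keeps the lower number against a ring-bearing group joined through oxygen as well as against one joined directly. Benzyloxy against 4-chlorophenyl gives a 1.6-fold lower number from compound 1 to compound 3 (0.21 log units; within the scatter) and so these two ring-bearing groups cannot be separated at this carbon. Nothing available gives a reason for either step.

Going by these compounds, whether the sulfur or the branched isopropyl chain goes with the lower number stays open. Isopropoxy or a dimethylamino group on the same carbon would separate the two.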